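The source may report more compounds than this note shows. Statements on the series, on what has been measured and on what is new or still open speak of the compounds shown alone.

Compound 1 `CCN(C)Cc1c(OC)cc(OC)c(C(=O)/C=C/c2ccccc2Cl)c1O` and compound 2 `COc1cc(OC)c2c(=O)cc(-c3ccccc3Cl)oc2c1CN1CCCCC1` have both been tested in a functional assay on Bel-7402 cells (Homo sapiens) for antiproliferative activity, with a stated time of 72 h; on this read-out higher numbers stand for weaker inhibition and lower numbers for stronger inhibition. Compound 1 gives 23300 nM, and compound 2 gives 44200 nM; these two numbers lie within the usual scatter of repeated measurements, so neither compound can be called the stronger inhibitor. Compound 3 `COC(=O)CN(C)Cc1c(OC)cc(OC)c(C(=O)/C=C/c2ccccc2Cl)c1O` has not yet been measured. It differs from compound 1 by methoxycarbonyl in place of methyl on a saturated chain carbon bound to an amine nitrogen. Within the data shown here, no measured pair shows what such a change does here, so for compound 3 a step of about a 1.1-fold higher number from compound 1 to compound 3 (0.03 log units; within the scatter) is expected, nothing beyond the scatter. Compound 3 is estimated at 25000 nM, within a range from 8000 nM to 80000 nM.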

Compound 3, half-maximal inhibitory concentration: 8500 nM
Compound 3: the middle estimate sits 2.9-fold (0.47 log units) above what was measured; measured number inside the range.
By their numbers in this assay, from the lowest: compound 3; then compounds 1 and 2 (each within the scatter of the next).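

In this assay, among these compounds, methoxycarbonyl in place of methyl on a saturated chain carbon bound to an amine nitrogen gives a 2.7-fold lower number from compound 1 to compound 3 (0.44 log units; beyond the scatter), the first step here between compounds that differ in one place. So this position is not silent: a change on this chain moves the number beyond the scatter, towards stronger inhibition. Nothing at hand gives a cause for this step. Going by these compounds, how a carboxylic acid, an amide or a plain propyl chain would read at this place remains open. So does which part of the methoxycarbonyl group matters.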